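The compounds below may be only part of what the source reports. "The series", "measured", "known", "first", "only" and "open" are said of these compounds alone.

Measured compounds:
Compound 1, `Oc1ccc(O)c(-c2cc(-c3ccc(Cl)cc3)nn2-c2ccccc2)c1`, gives 5750 nM in a functional assay on cells (Cancer cell lines, Homo sapiens) for cytotoxicity, read by sulforhodamine B assay, with a stated time of 48 h; on this read-out lower numbers stand for stronger inhibition of growth and higher numbers for weaker inhibition of growth.
Compound 2, `NS(=O)(=O)c1ccc(-n2nc(-c3ccccc3)cc2-c2cc(O)ccc2O)cc1`, gives 75700 nM in this assay.
Compound 3, `NS(=O)(=O)c1ccc(-n2nc(-c3ccc(Cl)cc3)cc2-c2cc(O)ccc2O)cc1`, gives 15100 nM in this assay.

Compound 3 stands second highest among the three numbers. Going by the values given here, its nearest neighbour is compound 1, from which the single exchange gives a 2.6-fold higher number from compound 1 to compound 3 (0.42 log units; beyond the scatter). Among the compounds with values here, its furthest neighbour is compound 2, from which the single exchange gives a 5.0-fold lower number from compound 2 to compound 3 (0.70 log units; beyond the scatter).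

Compound 4, `NS(=O)(=O)c1ccc(-n2nc(-c3ccc(Cl)cc3)cc2C2=CC(=O)C=CC2=O)cc1`, has not been measured. It differs from compound 3 in one place: a group of 8 heavy atoms (6 carbon, 2 oxygen; one six-membered non-aromatic ring of carbon only) in place of a group of 8 heavy atoms (6 carbon, 2 oxygen; one six-membered aromatic ring of carbon only), on an aromatic carbon. Neither of the measured steps touches this change. Both of them alter a substituent on a phenyl ring attached to the shared core, while the change to compound 4 converts the 2,5-dihydroxyphenyl group itself into a ring bearing two carbonyl groups and no hydrogen-bond donors. The measured steps therefore set only the scale of what single exchanges have done here, both modest, and give no direction for this one.

With nothing in the data pointing one way, compound 4 is expected to land near compound 3, with a wide range allowed, so that the estimated step is a 1.7-fold lower number from compound 3 to compound 4 (0.22 log units; within the scatter). Compound 4 is thus estimated at 9000 nM, expected to fall between 2000 nM and 40000 nM.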

Compound 4, concentration for 50% growth inhibition: 17600 nM
Compound 4: middle estimate off by 2.0-fold (0.29 log units), on the low side; the range from low to high includes it.
By their numbers in this assay, from the lowest: compound 1; then compounds 3 and 4 (each within the scatter of the next); then compound 2.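

In this assay, the earlier compounds had shown only exchanges on the phenyl groups, whereas this pair gives a first reading at the position on the five-membered ring that carried the 2,5-dihydroxyphenyl group in compound 3. Exchanging that group for the non-aromatic ring with two carbonyl groups gives the step (a 1.2-fold higher number from compound 3 to compound 4 (0.07 log units; within the scatter)), so this read-out does not tell compound 3 and compound 4 apart, and with the 4-sulfamoylphenyl and 4-chlorophenyl groups held fixed, the hydrogen-bond donors of the leaving group are not needed to stay at this level. Nothing available explains why the exchange leaves the two compounds indistinguishable here.

On these data alone, it remains open whether the same exchange would also leave the number in place on the scaffold of compound 1, which has a plain phenyl group on the ring nitrogen instead of the 4-sulfamoylphenyl group. Also open, as far as these compounds go, is how this position would respond to other groups, such as a 2,5-dimethoxyphenyl group, a plain phenyl group or a ring bearing an amine or a carboxylic acid, and whether any of these would move the number beyond the usual scatter.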